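The source may hold more compounds than are shown below. What is called first, only, known or untested is meant among the compounds shown, and "the series" means these compounds.

Measured in an ADME assay on cells (Hepatocyte, Homo sapiens) for metabolic stability, with a stated time of 30 min; on this read-out higher numbers stand for a more stable compound and lower numbers for a less stable compound:
- compound 1 `O=C(NC1CCC(CN2CCN(c3cc(=O)c4cc(C(F)(F)F)cc([N+](=O)[O-])c4s3)CC2)CC1)c1ccccc1`: 92.9%
- compound 2 `Nc1cc(C(F)(F)F)cc2c(=O)cc(N3CCN(CC4CCC(O)CC4)CC3)sc12`: 72.9%
- compound 3 `Nc1cc(C(F)(F)F)cc2c(=O)cc(N3CCN(CC4CCCCC4)CC3)sc12`: 0.9%

Of these three, compound 1 stands highest at 92.9%, with compound 2 nearest to it and compound 3 furthest away. The next compound to be tested in this assay is compound 4 `CC(=O)NC1CCC(CN2CCN(c3cc(=O)c4cc(C(F)(F)F)cc([N+](=O)[O-])c4s3)CC2)CC1`, which differs from compound 1 at a single place: methyl in place of phenyl on a carbonyl carbon. In words, this is methyl in place of phenyl on a carbonyl carbon, or benzamido to acetamido.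

Going by the values given here, only one measured step is available, and it bears on this change only weakly. It is a number 72 percentage points lower from compound 2 to compound 3 (beyond the scatter), a large step, but it concerns hydrogen in place of hydroxy on a saturated ring carbon. Neither compound 2 nor compound 3 carries the benzamido group, so no measurement shows what replacing the phenyl does here. That step does show that a single change can move this read-out a long way, so the range must stay wide. Among the compounds with values here, with no measured step at this place, no shift beyond the scatter is expected. The estimated a number 4.9 percentage points lower from compound 1 to compound 4 (within the scatter) is therefore expected to remain within the scatter. Compound 4 is expected at about 88%, with an estimated range from 68% to 100%.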

Compound 4, percent of the compound remaining: 86.8%
Estimate against measurement, compound 4: 1.2 percentage points above; the range from low to high includes it.
By their numbers in this assay, from the lowest: compound 3; then compound 2; then compounds 4 and 1 (each within the scatter of the next).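

In this assay, the change from benzamido to acetamido gives a number 6.1 percentage points lower from compound 1 to compound 4 (within the scatter), the first step measured at this place. Replacing phenyl with methyl on the carbonyl carbon removes the aromatic ring, yet the read-out does not separate the two compounds, so the phenyl is not needed for the high number seen with compound 1 in this series. Nothing measured here bears on the reason for this result, so no cause can be assigned to it.

The compounds shown leave open whether this insensitivity extends to other groups on the carbonyl carbon, such as a longer alkyl chain, a cyclohexyl ring or a carboxylic acid, or to replacing the whole amide with a free amine. They also leave open whether the same change would behave alike on the core of compound 2 and compound 3, since neither of those compounds carries an amide and only compound 1 and compound 4 show this step.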